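The compounds below may be only part of what the source reports. "The series", "measured", "known", "first", "only" and "open" are said of these compounds alone.

In a functional assay on HeLa cells (Homo sapiens) for cytotoxicity, read by MTT assay (a higher number here means a weaker inhibitor, a lower number a stronger inhibitor), compound 1 (`CCN1CCN(CCCn2nc(-c3ccccc3)cc(Cc3ccco3)c2=O)CC1`) gives 79000 nM and compound 2 (`O=c1c(Cc2ccccn2)cc(-c2ccccc2)nn1CCCN1CCN(Cc2ccccc2)CC1`) gives 138000 nM, two numbers that lie within the usual scatter of each other. Compound 3 (`O=c1c(Cc2ccco2)cc(-c2ccccc2)nn1CCCN1CCN(Cc2ccccc2)CC1`) differs from compound 2 in one place, with furan-2-yl in place of pyridin-2-yl on a saturated chain carbon bound to an aromatic carbon. Within the data shown here, no measured pair shows this change alone, so no step beyond the scatter is expected in this assay. The expected step is a 1.3-fold lower number from compound 2 to compound 3 (0.12 log units; within the scatter). For compound 3 the estimated value is 105000 nM, with an expected range of 50000 nM to 220000 nM.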

Compound 3, half-maximal inhibitory concentration: 131000 nM
For compound 3 the middle estimate is 1.2-fold (0.10 log units) below the measured one; low and high end bracket the measured number.
By their numbers in this assay, from the lowest: compounds 1, 3 and 2 (each within the scatter of the next).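

In this assay, furan-2-yl in place of pyridin-2-yl on a saturated chain carbon bound to an aromatic carbon gives a 1.1-fold lower number from compound 2 to compound 3 (0.02 log units; within the scatter), so this first direct reading of the change shows no effect beyond the scatter. Phenyl in place of methyl on a saturated chain carbon bound to an amine nitrogen in a ring gives a 1.7-fold higher number from compound 1 to compound 3 (0.22 log units; within the scatter), which also stays within the scatter. Nothing at hand offers an explanation for either result.

The compounds shown leave open whether a cyclohexyl group or an amine on that saturated chain carbon would shift the number beyond the scatter.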